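Removing One Methyl from Compound 3

A few compounds are considered here, and "the series" means these few. Any claim that something is new, unique, unknown or untested is made for them only; others in the source may bear on it.

Values measured in a functional assay on MCF7 cells (Homo sapiens) for antiproliferative activity, read by sulforhodamine B assay, with a stated time of 48 h; on this read-out higher numbers stand for weaker inhibition and lower numbers for stronger inhibition:
Compound 1 (`COc1ccc(OC)c(/C=C/C(=O)/C=C(O)/C=C/c2cc(OC)ccc2OC)c1`) gives > 50000 nM
Compound 2 (`COc1cccc(/C=C/C(=O)C(=Cc2ccc(O)c(F)c2)C(=O)/C=C/c2cccc(OC)c2OC)c1OC`) gives 300 nM
Compound 3 (`COc1ccc(OC)c(/C=C/C(=O)C(=Cc2ccc(OC)c(OC)c2)C(=O)/C=C/c2cc(OC)ccc2OC)c1`) gives 850 nM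

Compound 1 gives > 50000 nM as a limit of the assay and not as a number.

Only two of the three results in this assay are true numbers. Compound 3 has the higher of the two, at 850 nM on this read-out. Compound 2 gives 300 nM here, and that gap lies beyond the usual scatter. Compound 3 therefore stands as the weaker of the two compounds with numerical results.

Compound 4 (`COc1ccc(OC)c(/C=C/C(=O)C(=Cc2ccc(OC)c(O)c2)C(=O)/C=C/c2cc(OC)ccc2OC)c1`) has not yet been measured. It departs from compound 3 in a single place: hydrogen in place of methyl on an oxygen on an aromatic ring. Methoxy thus becomes hydroxy, and 3,4-dimethoxyphenyl becomes 3-hydroxy-4-methoxyphenyl.

Among the measured compounds shown here, no measured pair in this small set shows such a change directly, so the expectation rests on thin ground. Compound 2 also carries a hydroxy on an aromatic ring and gives 300 nM in this test. The step expected is modest and runs toward stronger inhibition (a 2.1-fold lower number from compound 3 to compound 4 (0.33 log units; beyond the scatter)). Compound 4 is estimated at 400 nM with an expected range from 130 nM to 1300 nM here.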

Compound 4, half-maximal inhibitory concentration: 990 nM
Compound 4: the middle estimate sits 2.5-fold (0.39 log units) below what was measured, and the stated range covers the measured number.
By their numbers in this assay, from the lowest: compound 2; then compounds 3 and 4 (each within the scatter of the next). At a limit, above all of these: compound 1.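

In this assay, among the compounds shown here, hydrogen in place of methyl on an oxygen on an aromatic ring gives a 1.2-fold higher number from compound 3 to compound 4 (0.07 log units; within the scatter), the first direct reading of this change in the set. At this position, then, 3,4-dimethoxyphenyl and 3-hydroxy-4-methoxyphenyl cannot be told apart on this read-out, and the methyl can be exchanged for hydrogen with no difference beyond the scatter. This pair lends no support to the idea that a hydroxy on an aromatic ring brings stronger inhibition by itself, compound 2 differs from compound 4 in more than one place, and nothing measured here offers a reason for the absence of a clear step.

On these data alone, one pair speaks for one place only, and whether the other methoxy groups on the shared core behave in the same way stays open. The compounds shown also leave open how a longer chain on this same oxygen, or an amine or a carboxylic acid in place of the hydroxy, would read in this assay.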